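Carbamate capping of the amine in the thiazolyl amide series

A few compounds are considered here, and "the series" means these few. Any claim that something is new, unique, unknown or untested is made for them only; others in the source may bear on it.

Among the compounds with values here, compound 2 `N[C@@H](CCCCNS(N)(=O)=O)C(=O)Nc1nc(-c2ccccc2)cs1` gives 1100 nM in an assay for inhibition of protein deacetylase HDAC6 (Homo sapiens) (a higher number here means a weaker inhibitor, a lower number a stronger inhibitor), the highest of the two numbers so far; compound 1 `NS(=O)(=O)NCCCC[C@H](NC(=O)OCc1ccccc1)C(=O)Nc1nc(-c2ccc(Cl)cc2)cs1`, which differs from it at two places, gives 250 nM in this assay. Compound 3 `NS(=O)(=O)NCCCC[C@H](NC(=O)OCc1cccnc1)C(=O)Nc1nc(-c2ccccc2)cs1` differs from compound 2 by ((pyridin-3-yl)methoxy)carbonyl in place of hydrogen on an amine nitrogen. Within the data shown here, no measured pair isolates this change. A step toward a lower number beyond the scatter is expected for the move a 3.1-fold lower number from compound 2 to compound 3 (0.50 log units; beyond the scatter), because compound 1 with a carbamate on that nitrogen gives 250 nM. Compound 3 is estimated at 350 nM, within a range from 150 nM to 800 nM.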

Compound 3, half-maximal inhibitory concentration: 600 nM
Beside the measured number, compound 3's estimate is 1.7-fold (0.23 log units) below it, within the range that was stated.
By their numbers in this assay, from the lowest: compound 1; then compounds 3 and 2 (each within the scatter of the next).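

Putting ((pyridin-3-yl)methoxy)carbonyl in place of hydrogen on the amine nitrogen gives a 1.8-fold lower number from compound 2 to compound 3 (0.26 log units; within the scatter) in this assay. The free amine is therefore not required for the number seen in this series, and this nitrogen carries the carbamate with no step beyond the scatter. No evidence bears on the reason for this result.

On these data alone, how much of the value of compound 1 comes from its benzyl carbamate and how much from its chlorine stays open. Also open, as far as these compounds go, is whether an acetyl amide or a urea on this nitrogen behaves like the carbamate.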